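Notes on the 3-oxopiperazin-1-yl step from compound 2

The source may report more compounds than this note shows. Statements on the series, on what has been measured and on what is new or still open speak of the compounds shown alone.

Compound 1 `CN1CCN(c2nc(N3CCCC3)c3nc(Cl)c(NCc4ccccc4)nc3n2)CC1` gives 6500 nM
Compound 2 `CC(=O)N1CCN(c2nc(N3CCCC3)c3nc(Cl)c(NCc4ccccc4)nc3n2)CC1` gives 13000 nM
Compound 3 `O=C1CN(c2nc(N3CCCC3)c3nc(Cl)c(NCc4ccccc4)nc3n2)CCN1` is not yet measured

In a functional assay (Homo sapiens) for inhibition, read by sulforhodamine B assay, with a stated time of 3 days (a lower number here means a stronger inhibitor, a higher number a weaker inhibitor), compound 2 at 13000 nM stands within the scatter of compound 1. The change to compound 3 is 3-oxopiperazin-1-yl in place of 4-acetylpiperazin-1-yl on an aromatic carbon on an aromatic carbon between two ring nitrogen atoms. For the measured compounds named here, only one measured step bears on this group, a 2.0-fold higher number from compound 1 to compound 2 (0.30 log units; within the scatter) and that step is small. In this assay the expected result is a 1.3-fold lower number from compound 2 to compound 3 (0.11 log units; within the scatter) and no step beyond the scatter is expected. Compound 3 is estimated at 10000 nM with a range from 4000 nM to 25000 nM as the expected spread.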

Compound 3, half-maximal inhibitory concentration: 9500 nM
Compound 3: the middle estimate sits 1.1-fold (0.02 log units) above what was measured; low and high end bracket the measured number.
By their numbers in this assay, from the lowest: compounds 1, 3 and 2 (each within the scatter of the next).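

In this assay, the step to the 3-oxopiperazin-1-yl group adds a hydrogen-bond donor at this aromatic carbon between two ring nitrogen atoms, and it gives a 1.4-fold lower number from compound 2 to compound 3 (0.14 log units; within the scatter) and a 1.5-fold higher number from compound 1 to compound 3 (0.16 log units; within the scatter). So neither the smaller group nor the added donor produces a step beyond the scatter in these three compounds. Nothing available accounts for these steps or links them to a measured property.

Still open, going by these compounds, is whether a morpholine ring or a piperazine carrying a free amine or a carboxylic acid chain at this position would move the number beyond the scatter. The three compounds also leave open how the pyrrolidin-1-yl group contributes.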